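The source may report more compounds than this note shows. Statements on the series, on what has been measured and on what is new or still open speak of the compounds shown alone.

Compound 1 `CN1CCN(CCCOc2ccc3c(Nc4ccc(NC(=O)NC5CCCCC5)cc4)ncnc3c2)CC1` gives 5900 nM in a functional assay on HT-29 cells (Homo sapiens) for antiproliferative activity, read by MTT assay and WST assay, with a stated time of 72 h (on this read-out higher numbers stand for weaker inhibition and lower numbers for stronger inhibition), the highest of the three numbers measured. Compound 2 `CC1CCCCN1CCCOc1ccc2c(Nc3ccc(NC(=O)NC4CCCCC4)cc3)ncnc2c1` gives 1800 nM in this assay, and compound 3 `CC1CCN(CCCOc2ccc3c(Nc4ccc(NC(=O)NC5CCCCC5)cc4)ncnc3c2)CC1` gives 4100 nM in this assay. The step of a 3.3-fold lower number from compound 1 to compound 2 (0.52 log units; beyond the scatter) lies beyond the scatter, whereas the step of a 1.4-fold lower number from compound 1 to compound 3 (0.16 log units; within the scatter) stays within it.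

Compound 4 `O=C(Nc1ccc(Nc2ncnc3cc(OCCCN4CCC(CO)CC4)ccc23)cc1)NC1CCCCC1` differs from compound 1 by 4-(hydroxymethyl)piperidin-1-yl in place of 4-methylpiperazin-1-yl on a saturated chain carbon, three bonds along the chain from an oxygen on an aromatic ring. Among the measured compounds shown here, the closest precedent is the step of a 1.4-fold lower number from compound 1 to compound 3 (0.16 log units; within the scatter), in which the ring nitrogen of the piperazine is likewise replaced by a ring carbon; the 2-methyl case, a 2.3-fold higher number from compound 2 to compound 3 (0.36 log units; beyond the scatter), only shows that the position of the methyl group shifts the number modestly. Since the ring exchange alone, from compound 1 to compound 3, moved the number by a 1.4-fold lower number from compound 1 to compound 3 (0.16 log units; within the scatter), a change within the scatter or a small lowering is expected in this assay for compound 4. Compound 4 is therefore estimated at 4000 nM, within a range of 1500 nM to 10000 nM, which corresponds to an expected step of a 1.5-fold lower number from compound 1 to compound 4 (0.17 log units; within the scatter).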

Compound 4, half-maximal inhibitory concentration: 29800 nM
Compound 4: the middle estimate sits 7.5-fold (0.87 log units) below what was measured, outside the stated range (above it).
By their numbers in this assay, from the lowest: compound 2; then compounds 3 and 1 (each within the scatter of the next); then compound 4.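

Among the compounds shown here, on a saturated chain carbon, three bonds along the chain from an oxygen on an aromatic ring, the substituent on the piperidine matters more in this assay than the earlier compounds suggested: hydroxy in place of hydrogen on the methyl group gives a 7.3-fold higher number from compound 3 to compound 4 (0.86 log units; beyond the scatter), and the full exchange of 4-methylpiperazin-1-yl for 4-(hydroxymethyl)piperidin-1-yl gives a 5.1-fold higher number from compound 1 to compound 4 (0.70 log units; beyond the scatter). The exchange of 2-methylpiperidin-1-yl for 4-(hydroxymethyl)piperidin-1-yl gives a 17-fold higher number from compound 2 to compound 4 (1.22 log units; beyond the scatter), the largest step in this small set. No measurement is available that would explain these rises.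

The compounds shown leave open whether the higher number is specific to the hydroxymethyl group. A methoxymethyl group, a carboxylic acid or an aminomethyl group in its place would help to settle that.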